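A few compounds are considered here, and "the series" means these few. Any claim that something is new, unique, unknown or untested is made for them only; others in the source may bear on it.

Measured in a physicochemical assay for solubility, at pH 6.8; a higher number here means a more soluble compound, a lower number a less soluble compound:
- Compound 1 `Cc1c(COc2ccnc(OCC3CCOCC3)c2)[nH]c2ccccc2c1=O`: 22000 nM
- Compound 2 `Cc1ccc2[nH]c(COc3cccc(OCC4CCOCC4)c3)c(C)c(=O)c2c1`: < 1000 nM, a limit
- Compound 3 `Cc1c(COCCCCO)[nH]c2ccccc2c1=O`: >= 100000 nM, a limit

Compound 2 stands at the limit of < 1000 nM in this assay, at which 1 of the 3 values shown sits, so its entry is a limit of this assay and not a number. Of the three compounds, it is the one at the low end of the scale. Compound 1 has a true number, but it differs from compound 2 in more than one place.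

Compound 4 `Cc1c(COc2cccc(OCC3CCOCC3)c2)[nH]c2ccccc2c1=O` is compound 2 with one small edit: hydrogen in place of methyl on an aromatic carbon. That carbon sits on a six-membered aromatic ring of carbon only, part of a fused or bridged system of two rings.

For the measured compounds named here, no two measured compounds differ in one place, so no measured step shows what this edit does in this assay. With only one heavy atom leaving, a small upward move is the expectation, and a large one is not. The estimated step is an at least 1.2-fold higher number from compound 2 to compound 4 (0.07 log units; that floor lies within the scatter), and it is rough, as its starting point is only a limit. A reading that is again only a limit would be no surprise.

For compound 4, the expected value is 1200 nM, with an estimated range of 500 nM to 4000 nM.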

Compound 4, solubility: 5000 nM
For compound 4 the middle estimate is 4.2-fold (0.62 log units) below the measured one; the measured number lies above the stated range.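

Swapping the methyl on this aromatic carbon for hydrogen gives the first comparison here between two compounds that differ in one place: in this assay, the change produces an at least 5.0-fold higher number from compound 2 to compound 4 (0.69 log units; beyond the scatter). The true size of that step stays unknown, and it can be read only as a floor, because the value of compound 2 is a limit of the assay and not a number: the limit of < 1000 nM in this assay, at which 1 of the 4 values shown sits.

Compound 4, by contrast, gives a true number of 5000 nM, which shows that at this position, meta to a fused ring and para to a fused ring, the loss of one heavy atom is enough to move the reading beyond the scatter.

From the compounds shown here alone, what remains open is how far the reading would move with other groups on this same carbon, such as a chlorine atom, a methoxy group or an amine, and whether any of them would shift it in the opposite direction. This single pair also leaves open whether the same edit would give a step of similar size on a different core or with a different side chain.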